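This account rests on a few compounds, and the source may have more. Where it says the series, first, only, none or still open, it means among the compounds named here.

Measured in a functional assay on MCF7 cells (Homo sapiens) for inhibition, read by sulforhodamine B assay; on this read-out lower numbers stand for stronger inhibition of growth and higher numbers for weaker inhibition of growth:
- compound 1 `Cc1ccc2[nH]c(-c3ccc(-c4ccc(-c5ccc(N(C)C)cc5)cc4)cc3)nc2c1` gives 3130 nM
- compound 2 `Cc1ccc2[nH]c(-c3ccc(-c4ccc(-c5cccc(Cl)c5)cc4)cc3)nc2c1` gives 1210 nM
- compound 3 `COc1ccc(-c2ccc(-c3ccc(-c4nc5cc(C)ccc5[nH]4)cc3)cc2)cc1OC` gives 190 nM

Compound 3 stands lowest of the three: a 16-fold lower number from compound 1 to compound 3 (1.22 log units; beyond the scatter) and a 6.4-fold lower number from compound 2 to compound 3 (0.80 log units; beyond the scatter), both beyond the scatter, while a 2.6-fold lower number from compound 1 to compound 2 (0.41 log units; beyond the scatter). Compound 4 `COc1cc(-c2ccc(-c3ccc(-c4nc5cc(C)ccc5[nH]4)cc3)cc2)cc(OC)c1OC` keeps the core of compound 3 and differs by methoxy in place of hydrogen on an aromatic carbon, the entering group ortho to a methoxy group and meta to a large group. Among the measured compounds shown here, no measured step adds a methoxy to a ring already bearing one; the two steps reaching compound 3 swap whole terminal groups and so set the scale of what this position tolerates, not the direction of a third methoxy. A step within or near the scatter is therefore expected in this assay. Compound 4 is estimated at 150 nM, between 50 nM and 600 nM. This expected value means a 1.3-fold lower number from compound 3 to compound 4 (0.10 log units; within the scatter).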

Compound 4, concentration for 50% growth inhibition: 170 nM
The estimate for compound 4 lay 1.1-fold (0.05 log units) below the measured number; the range from low to high includes it.
By their numbers in this assay, from the lowest: compounds 4 and 3 (each within the scatter of the next); then compound 2; then compound 1.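

In this assay, methoxy in place of hydrogen, ortho to a methoxy group and meta to a second one, leaves the number within the scatter (a 1.1-fold lower number from compound 3 to compound 4 (0.05 log units; within the scatter)). The earlier steps shown here swapped whole terminal groups, whereas this one adds a single group to a ring already bearing methoxy groups, and this position accepts that addition without a change beyond the scatter. No available evidence speaks to the reason for this result. Still open, from the compounds shown here alone, is how a hydroxy group, an amine or a longer alkoxy chain would behave at this same position.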